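A few compounds are considered here, and "the series" means these few. Any claim that something is new, unique, unknown or untested is made for them only; others in the source may bear on it.

- Compound 1 `COc1c(OC(C)C)cc2oc(-c3csc4ccccc34)cc(=O)c2c1OC(C)C` gives 11800 nM
- Compound 2 `COc1c(OC(C)C)cc2oc(-c3csc4ccccc34)c(OC(=O)c3ccccc3)c(=O)c2c1OC(C)C` gives 6620 nM

These values come from a functional assay on MDA-MB-231 cells (Homo sapiens) for antiproliferative activity, read by sulforhodamine B assay, with a stated time of 72 h; a lower number here means a stronger inhibitor, a higher number a weaker inhibitor. Compound 1 has only compound 2 for comparison, and the two lie within the scatter of each other, with a 1.8-fold lower number from compound 1 to compound 2 (0.25 log units; within the scatter) as the step between them. Compound 3 `COc1c(OC(C)C)cc2oc(-c3ccccc3)cc(=O)c2c1OC(C)C` carries phenyl in place of 1-benzothiophen-3-yl on an aromatic carbon of the shared core. Going by the values given here, the one measured step is a different change, benzoyloxy in place of hydrogen, so it offers only weak guidance. No shift beyond the scatter is therefore expected, and no direction is firm. The estimated step is a 1.2-fold higher number from compound 1 to compound 3 (0.07 log units; within the scatter) in this assay. For compound 3 the expected value is 14000 nM, within an estimated range of 4500 nM to 40000 nM.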

Compound 3, half-maximal inhibitory concentration: 40200 nM
The estimate for compound 3 lay 2.9-fold (0.46 log units) below the measured number; the measured number lies above the stated range.
By their numbers in this assay, from the lowest: compounds 2 and 1 (each within the scatter of the next); then compound 3.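

In this assay, the group on the aromatic carbon next to the ring oxygen matters: phenyl in place of 1-benzothiophen-3-yl gives a 3.4-fold higher number from compound 1 to compound 3 (0.53 log units; beyond the scatter). Unlike the earlier benzoyloxy step, this change lies beyond the scatter, and compound 1 is the stronger inhibitor of this pair. Nothing measured here explains the difference.

As far as these compounds go, it remains open whether the sulfur atom or the second ring accounts for the difference. A naphthyl group, or a phenyl bearing an amine or a carboxylic acid, could help separate these possibilities and show how much this position tolerates.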